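From 1-propyl-1H-pyrazol-4-yl to 2-chloropyridin-4-yl

A few compounds are considered here, and "the series" means these few. Any claim that something is new, unique, unknown or untested is made for them only; others in the source may bear on it.

Compound 1 `CCCn1cc(-c2cnc(NCc3ccc4sccc4c3)c(C(=O)NCC3COc4ccccc4O3)c2)cn1`: > 95%
Compound 2 `CCCn1cc(-c2cnc(NCc3ccc4c(c3)OCC4)c(C(=O)NCC3COc4ccccc4O3)c2)cn1`: > 95%

In an assay on HEK293 cells for agonist activity at growth hormone secretagogue receptor type 1 (Rattus norvegicus), read by a luciferase reporter (on this read-out higher numbers stand for larger maximal responses and lower numbers for smaller maximal responses), compound 1 reaches > 95%, which is a limit of the assay rather than a number. Compound 2 likewise reaches > 95%, again a limit. The step that the two limits leave unreadable from compound 1 to compound 2 therefore cannot be read, since both values sit at the limit (the limit of > 95% in this assay, at which 2 of the 2 values shown sit). Compound 2 thus stands at the top of what this assay reports. Compound 3 `O=C(NCC1COc2ccccc2O1)c1cc(-c2ccnc(Cl)c2)cnc1NCc1ccc2c(c1)OCC2` differs from compound 2 by 2-chloropyridin-4-yl in place of 1-propyl-1H-pyrazol-4-yl on an aromatic carbon. No measured step touches this part of the shared core, so nothing shown speaks to the size or direction of this change in this assay. Compound 3 is therefore expected to remain near the limit, with its maximal response estimated at 88% (range 55% to 100%). The step of a number at least 7 percentage points lower from compound 2 to compound 3 (that floor lies within the scatter) is expected to be small, a guess not backed by any measured comparison.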

Compound 3, largest response reached (reported as efficacy), in percent of the reference or control that the assay uses: > 95%
Compound 3 ended at the assay's limit; the forecaster's own chance of this, stated with the estimate: 40%; middle value at least 7 percentage points from the limit.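

Compound 2 and compound 3 sit at the same limit in this assay, so the step between them cannot be read: the limit of > 95% in this assay, at which 3 of the 3 values shown sit.

The compounds shown leave open whether 2-chloropyridin-4-yl in place of 1-propyl-1H-pyrazol-4-yl changes the maximal response at all, and how large any such change would be.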